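Working notes: 2-methoxy-1-(methoxymethyl)ethyl in place of pentan-3-yl

This account rests on a few compounds, and the source may have more. Where it says the series, first, only, none or still open, it means among the compounds named here.

Compound 1 `CCc1nc(-c2ccc(Cl)cc2Cl)c(CC)nc1NC(CC)CC` is the reference point of the pair measured so far. In an assay on IMR-32 cells for displacement of a labelled ligand from corticotropin-releasing factor receptor 1 (Homo sapiens), read by scintillation counting, with a stated time of 2 h (on this read-out higher numbers stand for weaker inhibition and lower numbers for stronger inhibition), compound 1 gives 4.1 nM, the lowest of the two numbers in hand. For the measured compounds named here, its only measured neighbour is compound 2 `CCc1nc(-c2ccc(Cl)cc2Cl)c(OC)nc1NC(CC)CC`, which in this assay gives 8 nM. The step of a 2.0-fold higher number from compound 1 to compound 2 (0.29 log units; within the scatter) lies within the scatter, so the two compounds cannot be ordered against each other; it also concerns a substituent on an aromatic carbon, not the amino side of the core.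

Compound 3 `CCc1nc(-c2ccc(Cl)cc2Cl)c(CC)nc1NC(COC)COC` has not yet been measured. Against compound 1 the change is 2-methoxy-1-(methoxymethyl)ethyl in place of pentan-3-yl on a nitrogen on an aromatic ring. Going by the values given here, no measured step in the set touches the nitrogen on the aromatic ring, so there is no direct precedent for the effect of the two oxygens entering with 2-methoxy-1-(methoxymethyl)ethyl. Among the compounds with values here, the single step that exists, within the scatter, says nothing about this position. With that absence the working expectation is a modest weakening, the step of a 3.7-fold higher number from compound 1 to compound 3 (0.56 log units; beyond the scatter) being the guess. For compound 3 in this assay the estimate is 15 nM, with a range from 4 nM to 60 nM.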

Compound 3, inhibition constant: 224 nM
Compound 3: middle estimate off by 15-fold (1.17 log units), on the low side; measured number outside the range, above it.
By their numbers in this assay, from the lowest: compounds 1 and 2 (each within the scatter of the next); then compound 3.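

In this assay, the amino side of the core proves highly sensitive to this change: 2-methoxy-1-(methoxymethyl)ethyl in place of pentan-3-yl on a nitrogen on an aromatic ring gives a 55-fold higher number from compound 1 to compound 3 (1.74 log units; beyond the scatter), a large step beyond the scatter. The entering group keeps the 5 carbon of the leaving group and adds 2 oxygen and 2 hydrogen-bond acceptors, with no ring and no net charge on either side, whereas methoxy in place of ethyl on an aromatic carbon gives only a 2.0-fold higher number from compound 1 to compound 2 (0.29 log units; within the scatter), so the two sites of the core do not respond alike to these oxygen-bearing replacements. No measured information on the reason for this loss is available.

The compounds shown leave open whether a single ether oxygen, as in a group carrying one methoxymethyl arm and one ethyl arm, would give a step of similar size, or whether a hydroxyl or an amine on the same chain would behave as the two methoxy ends do. They also leave open whether the same side-chain change on the methoxy-bearing core of compound 2 would give a comparable step.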